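The source may report more compounds than this note shows. Statements on the series, on what has been measured and on what is new or still open speak of the compounds shown alone.

Compounds measured in a functional assay on EBC-1 cells (Homo sapiens) for antiproliferative activity, with a stated time of 72 h; a lower number here means a stronger inhibitor, a higher number a weaker inhibitor:
compound 1 `OCCn1cc(-c2cc(F)c3ncc(Cc4ccc5ncccc5c4)n3c2)cn1` gives 0.34 nM
compound 2 `Fc1cc(F)cc(-c2cc(F)c3ncc(Cc4ccc5ncccc5c4)n3c2)c1` gives 790 nM
compound 3 `N#Cc1ccc(-c2cc(F)c3ncc(Cc4ccc5ncccc5c4)n3c2)cc1F` gives 145 nM

Compound 3 sits second highest of the three numbers: its nearest neighbour is compound 2, reached by a 5.4-fold lower number from compound 2 to compound 3 (0.74 log units; beyond the scatter), while compound 1 lies far off, as a 430-fold higher number from compound 1 to compound 3 (2.63 log units; beyond the scatter) shows.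

Compound 4 `O=C(NC1CCOCC1)c1ccc(-c2cc(F)c3ncc(Cc4ccc5ncccc5c4)n3c2)cc1F` keeps the shared core of compound 3 and differs in one place: (oxan-4-yl)carbamoyl in place of cyano on an aromatic carbon

Going by the values given here, no measured step changes only this group at this position. The steps that exist swap the whole aryl group on the core, and they span a wide range: a 2300-fold higher number from compound 1 to compound 2 (3.37 log units; beyond the scatter), a 430-fold higher number from compound 1 to compound 3 (2.63 log units; beyond the scatter) and a 5.4-fold lower number from compound 2 to compound 3 (0.74 log units; beyond the scatter). They show that the group at this position controls the number strongly, and that compound 1, whose group brings a hydrogen-bond donor, gives the lowest number. Since the entering (oxan-4-yl)carbamoyl also brings one hydrogen-bond donor and two acceptors, a lower number in this assay is expected, though a guess without a direct precedent; the expected step is a 5.8-fold lower number from compound 3 to compound 4 (0.76 log units; beyond the scatter).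

Compound 4 is therefore estimated at 25 nM, with a plausible range from 4 nM to 150 nM.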

Compound 4, half-maximal inhibitory concentration: 70.5 nM
For compound 4 the middle estimate is 2.8-fold (0.45 log units) below the measured one; the measured number falls inside the stated range.
By their numbers in this assay, from the lowest: compound 1; then compound 4; then compound 3; then compound 2.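

The cyano group ortho to a fluoro group can be replaced by the much larger (oxan-4-yl)carbamoyl, with nine heavy atoms instead of two and a six-membered non-aromatic ring, without any loss in this assay: the result is a 2.1-fold lower number from compound 3 to compound 4 (0.31 log units; beyond the scatter), a modest gain that lies beyond the scatter. Going by these compounds alone, this is the first comparison that keeps the fluorophenyl group on the shared core and changes only its substituent, so it shows that this outer spot accepts considerable bulk, while the printed values show that a hydrogen-bond donor in the entering group does not by itself close the gap, with compound 4 at 70.5 nM and compound 1 at 0.34 nM. Nothing available explains why the number moves in this direction.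

The compounds shown leave open which part of the new group matters: the carbonyl, the amide hydrogen or the oxane ring. Within the data shown here, a plain primary carboxamide, or a morpholine amide with no amide hydrogen, at this same place would begin to separate these parts, and a pyrazole carrying the 2-hydroxyethyl chain remains the only group here with a number close to that of compound 1.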